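Replacing a butylsulfanyl group on a shared core

The compounds below may be only part of what the source reports. "The series", "measured", "known", "first", "only" and "open" are said of these compounds alone.

Of the compounds shown here, three have been measured in an assay for inhibition of 15-hydroxyprostaglandin dehydrogenase [NAD(+)] (Homo sapiens), read by fluorescence, with a stated time of 15 min, in the presence of a further agent that is not named here; a higher number here means a weaker inhibitor, a lower number a stronger inhibitor. Compound 1 `CCCC[S+]([O-])c1sc2nc(-c3nccs3)cc(-c3cnc(C)[nH]3)c2c1N` gives 2.3 nM in this assay. Compound 3 `CCC[S+]([O-])c1sc2nc(-c3cccs3)cc(C(=O)OCC)c2c1N` gives 2 nM. Compound 2 `CCCCSc1sc2nc(-c3cccs3)cc(-c3ccccc3)c2c1N` returns only a limit, > 80 nM, so no number is known for it. Compound 2 thus stands at the limit of > 80 nM in this assay, at which 1 of the 3 values shown sits. Compound 4 `Nc1c([S+]([O-])CCCCl)sc2nc(-c3cccs3)cc(-c3ccccc3)c12` differs from compound 2 in one place: a group of 6 heavy atoms (3 carbon, 1 oxygen, 1 sulfur, 1 chlorine; no ring) in place of a group of 5 heavy atoms (4 carbon, 1 sulfur; no ring), on an aromatic carbon. Within the data shown here, no step between measured compounds is available, so the size of this change cannot be read from any measured pair. Compound 4 is nevertheless expected to inhibit clearly more strongly than the limit of compound 2; the expected step of an at least 16-fold lower number from compound 2 to compound 4 (1.20 log units; beyond the scatter) lies beyond the usual scatter, toward stronger inhibition. Compound 4 is estimated at 5 nM, between 1 nM and 40 nM.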

Compound 4, half-maximal inhibitory concentration: 4 nM
The estimate for compound 4 lay 1.3-fold (0.10 log units) above the measured number; the range from low to high includes it.
By their numbers in this assay, from the lowest: compounds 3, 1 and 4 (each within the scatter of the next). At a limit, above all of these: compound 2.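

This position on the shared core clearly matters: exchanging butylsulfanyl for the chlorine-ended, oxygen-bearing group of compound 4 gives an at least 20-fold lower number from compound 2 to compound 4 (1.30 log units; beyond the scatter). The rest of the molecule stays the same, so this large gain in inhibition comes from this one place. The step is only a minimum, since compound 2 is known only as a limit: the limit of > 80 nM in this assay, at which 1 of the 4 values shown sits.

As far as these compounds go, whether the oxygen on the sulfur or the chlorine on the chain carries the gain stays open. So does how an amine or a longer chain would fare at this carbon.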